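A few compounds are considered here, and "the series" means these few. Any claim that something is new, unique, unknown or untested is made for them only; others in the source may bear on it.

Measured in this assay:
compound 1 `CCN(CC)C(=O)C1=C(C)NC(=O)NC1c1ccco1`: 31%
compound 2 `CCN(CC)C(=O)C1=C(C)NC(=O)NC1c1ccoc1`: 12%
compound 3 `CCN(CC)C(=O)C1=C(C)NC(=O)NC1c1ccsc1`: 11%

In an assay on membranes from HEK293 cells for displacement of a labelled ligand from adenosine receptor A2b (Homo sapiens), read by scintillation counting, with a stated time of 30 min, tested at 1 uM (on this read-out higher numbers stand for more inhibition at the one concentration tested (going by the name of the read-out) and lower numbers for less inhibition), compound 3 gives the lowest of the three numbers, but the step of a number 1 percentage points lower from compound 2 to compound 3 (within the scatter) is within the scatter, so compounds 2 and 3 cannot be separated. Compound 1 stands apart: a number 20 percentage points lower from compound 1 to compound 3 (beyond the scatter) and a number 19 percentage points lower from compound 1 to compound 2 (beyond the scatter) are both beyond the scatter.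

Compound 4 `CC1=C(C(=O)OC2CCCCC2)C(c2ccsc2)NC(=O)N1` is the next member. It differs from compound 3 as follows: cyclohexyloxy in place of diethylamino on a carbonyl carbon. Within the data shown here, none of the measured steps bears on this change; all three vary the group on the saturated ring carbon and leave the carbonyl carbon untouched. No step size can therefore be taken over, and no change beyond the scatter is expected: a number 4 percentage points higher from compound 3 to compound 4 (within the scatter) is the estimated step. Compound 4 is expected to give 15%, within 0% to 45%.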

Compound 4, a percentage reported as inhibition, at one concentration (the size of the read-out at that concentration, not a potency): 4%
Estimate against measurement, compound 4: 11 percentage points above; measured number inside the range.
By their numbers in this assay, from the lowest: compounds 4, 3 and 2 (each within the scatter of the next); then compound 1.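

Among these compounds, this is the first reading of a change on the carbonyl carbon: in this assay, with thiophen-3-yl held constant, cyclohexyloxy in place of diethylamino gives a number 7 percentage points lower from compound 3 to compound 4 (within the scatter), so the two groups cannot be separated here. The added six-membered carbon ring and hydrogen-bond acceptor thus bring no gain beyond the scatter on this low-reading background. No available evidence explains the result.

Going by these compounds, it remains open whether cyclohexyloxy would read the same with furan-2-yl on the saturated ring carbon, as in compound 1. On these data alone, how an ethoxy or benzylamino group would read on the carbonyl carbon also remains open.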